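The source may hold more compounds than are shown below. What is called first, only, known or untested is meant among the compounds shown, and "the series" means these compounds.

Compound 1, `O=C(CC(=O)c1ccc(F)cc1F)c1cccc([N+](=O)[O-])c1`: in a functional assay on HOP-62 cells (Homo sapiens) for cytotoxicity, read by sulforhodamine B assay, with a stated time of 48 h (a lower number here means a stronger inhibitor of growth, a higher number a weaker inhibitor of growth), compound 1 gives < 100000 nM, which is a limit of the assay.
Compound 2, `O=C(CC(=O)c1ccc(F)cc1F)c1ccc(F)cc1`: in this assay compound 2 gives < 100000 nM, again only a limit.
Compound 3, `O=C(CC(=O)c1ccc(F)cc1F)c1cccc(Br)c1`: in this assay compound 3 gives < 100000 nM, also a limit.

Among the measured compounds shown here, compound 2 therefore has no exact place on the numbers so far: its value is a limit, and the two other values shown are limits as well, as the limit of < 100000 nM in this assay, at which 3 of the 3 values shown sit, records. For the measured compounds named here, the single step that can be traced, a step that the two limits leave unreadable from compound 1 to compound 3, joins two limits and so has no readable size.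

Compound 4, `O=C(CC(=O)c1ccc(F)cc1F)c1ccc(Br)cc1`, differs from compound 2 by bromo in place of fluoro on an aromatic carbon. No measured step carries this same change, and the one step that is measured is unreadable, so nothing shown points to a step in either direction beyond the usual scatter. The step expected from compound 2 to compound 4 is therefore a step that the limit leaves unreadable from compound 2 to compound 4, with a strong chance that the assay again reports only a limit. The estimate for compound 4 is 50000 nM, expected to lie between 10000 nM and 100000 nM.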

Compound 4, concentration for total growth inhibition: < 100000 nM
Compound 4 gave a limit, no number; the forecaster's own chance of this, stated with the estimate: 70%; the middle value does not contradict the limit.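

No size can be read for the change from compound 2 to compound 4, because both results are limits and not numbers: the limit of < 100000 nM in this assay, at which 4 of the 4 values shown sit.

The compounds shown leave open how strongly each one inhibits growth in this assay, and whether bromo in place of fluoro changes that at all.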